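The source may report more compounds than this note shows. Statements on the series, on what has been measured and on what is new or still open speak of the compounds shown alone.

In a physicochemical assay for lipophilicity, at pH 7.4 (a higher number here means a more lipophilic compound, a lower number a more polar compound), three related compounds have been measured so far. Compound 2 `C[C@H]1C(=O)N(C)C=Cc2ccccc21` gives 4.3, the middle of the three numbers: compound 3 `CCOc1ccc2c(c1)C=CN(C)C(=O)C2C` stands higher at 5 and compound 1 `COc1cc2c(cc1OC)[C@H](C)C(=O)N(C)C=C2` stands lower at 3.4, both gaps beyond the scatter. Compound 4 `COCCOc1ccc2c(c1)C=CN(C)C(=O)[C@@H]2C` comes from compound 2 by placing 2-methoxyethoxy in place of hydrogen on an aromatic carbon. Among the compounds with values here, no measured pair differs in one place only, so nothing shows this change directly. Compound 3 at 5 and compound 1 at 3.4 fall on opposite sides of compound 2, which points to no clear direction. The expected change a number 0.10 log units higher from compound 2 to compound 4 (within the scatter) is a slight rise, within the scatter. Compound 4 is estimated at 4.4, with an expected range from 3.8 to 5.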

Compound 4, distribution coefficient: 4
Estimate against measurement, compound 4: 0.40 log units above, within the range that was stated.
By their numbers in this assay, from the lowest: compound 1; then compounds 4 and 2 (each within the scatter of the next); then compound 3.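

Within the data shown here, this is the first direct reading of the change: in this assay, 2-methoxyethoxy in place of hydrogen on an aromatic carbon gives a number 0.30 log units lower from compound 2 to compound 4 (within the scatter). Among these compounds, at this position, then, the added chain brings no step that stands clear of the scatter. Nothing shown gives a measured reason for this result. The compounds shown leave open how an amine, a carboxylic acid or a longer chain would read at this same carbon. They also leave open whether 2-methoxyethoxy would give a similar step at another carbon of the same aromatic ring.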